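Replacing furan-3-yl with 3-isopropoxyphenyl in a cytotoxicity series

The source may report more compounds than this note shows. Statements on the series, on what has been measured and on what is new or still open speak of the compounds shown alone.

Compound 2 `CCOC(=O)CCCCCOc1cccc(CN(C(=O)c2ccc(-c3ccoc3)cc2)C(C)C)c1` carries a furan-3-yl group on the shared core. In an ADME assay on HEK293 cells (Homo sapiens) for cytotoxicity, read by CellTiter-Glo and resazurin assay, with a stated time of 72 h (on this read-out lower numbers stand for an effect already at smaller amounts and higher numbers for an effect only at larger amounts of compound), compound 2 gives > 26000 nM, which is a limit of the assay and not a number. Among the measured compounds shown here, compound 1 `CCOC(=O)CCCCCOc1cccc(CN(C(=O)c2ccc(-c3cccc(C(C)=O)c3)cc2)C(C)C)c1` is the only other compound measured alongside it. In this assay compound 1 gives > 26000 nM, again a limit rather than a number. The step from compound 1 to compound 2, a step that the two limits leave unreadable from compound 1 to compound 2, cannot be read because the limit of > 26000 nM in this assay, at which 2 of the 2 values shown sit, places both values at the same limit.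

Compound 3 `CCOC(=O)CCCCCOc1cccc(CN(C(=O)c2ccc(-c3cccc(OC(C)C)c3)cc2)C(C)C)c1` differs from compound 2 by 3-isopropoxyphenyl in place of furan-3-yl on an aromatic carbon. For the measured compounds named here, only one measured step touches this part of the structure, a step that the two limits leave unreadable from compound 1 to compound 2, and its size is hidden behind the limit, so it gives no readable guidance. The numbers therefore offer no ground for any change beyond the scatter. The step expected in this assay is a number no higher from compound 2 to compound 3 (the limit leaves the size open). Compound 3 is accordingly estimated at 26000 nM in this assay, with an expected range from 13000 nM to 52000 nM, most likely reported again as a limit.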

Compound 3, half-maximal effective concentration: > 26000 nM
Compound 3 gave a limit, no number; the forecaster's own chance of this, stated with the estimate: 85%; the middle value sits exactly at the limit.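

In this assay compound 3 gives > 26000 nM, which is a limit of the assay and not a number. Among the compounds shown here, no step between compound 1, compound 2 and compound 3 can be read, because all three sit at one limit: the limit of > 26000 nM in this assay, at which 3 of the 3 values shown sit. The compounds shown leave open whether 3-acetylphenyl, furan-3-yl and 3-isopropoxyphenyl differ at all in this assay.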